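A few compounds are considered here, and "the series" means these few. Any claim that something is new, unique, unknown or untested is made for them only; others in the source may bear on it.

Working notes on the series. Compound 1 `COc1ccc(S(=O)(=O)Nc2cccc3cc[nH]c23)cc1` in a functional assay on P388 cells (Mus musculus) for antiproliferative activity (on this read-out lower numbers stand for stronger inhibition and higher numbers for weaker inhibition), gives 1.1 ug/mL. Compound 2 `N#Cc1ccc(S(=O)(=O)Nc2cccc3cc[nH]c23)cc1` in this assay gives 4.2 ug/mL; it differs from compound 1 by cyano in place of methoxy on an aromatic carbon, and the step is a 3.8-fold higher number from compound 1 to compound 2 (0.58 log units; beyond the scatter). Compound 3 `COc1ccc(S(=O)(=O)Nc2cccc3c(Cl)c[nH]c23)cc1` in this assay gives 0.76 ug/mL; it differs from compound 1 by chloro in place of hydrogen on an aromatic carbon, and the step of a 1.4-fold lower number from compound 1 to compound 3 (0.16 log units; within the scatter) lies within the scatter, so no order between compound 1 and compound 3 is claimed. Between compound 3 and compound 2 the two numbers differ beyond the scatter, compound 2 showing the higher one.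

Compound 4 `N#Cc1ccc(S(=O)(=O)Nc2cccc3c(Cl)c[nH]c23)cc1` is not yet measured. It differs from compound 3 by cyano in place of methoxy on an aromatic carbon, the same change as from compound 1 to compound 2, at a place described in the same words; the change occurs twice among these compounds, once measured. The two cores differ by chloro in place of hydrogen on an aromatic carbon.

The step from compound 3 to compound 4 in this assay is expected to be about a 3.8-fold higher number from compound 3 to compound 4 (0.58 log units; beyond the scatter), beside the measured 3.8-fold higher number from compound 1 to compound 2 (0.58 log units; beyond the scatter). This rests on that single precedent and on the core step a 1.4-fold lower number from compound 1 to compound 3 (0.16 log units; within the scatter) lying within the scatter, with no second instance to check it. Compound 4 is therefore expected to give 2.9 ug/mL, roughly between 1.4 ug/mL and 6 ug/mL.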

Compound 4, half-maximal inhibitory concentration: 1.4 ug/mL
Estimate against measurement, compound 4: 2.1-fold (0.32 log units) above; measured number inside the range.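

In this assay, cyano in place of methoxy gives a 1.8-fold higher number from compound 3 to compound 4 (0.27 log units; within the scatter), and this step does not differ from the one measured on the core of compound 1: the same change on two cores in this assay, a 3.8-fold higher number (0.58 log units; beyond the scatter) from compound 1 to compound 2 and a 1.8-fold higher number (0.27 log units; within the scatter) from compound 3 to compound 4, 2.1-fold (0.32 log units) apart, within the scatter of two such steps. Chloro in place of hydrogen, read on the cyano pair, gives a 3.0-fold lower number from compound 2 to compound 4 (0.48 log units; beyond the scatter), and this step likewise does not differ from the one on the methoxy pair: the same change on two cores in this assay, a 1.4-fold lower number (0.16 log units; within the scatter) from compound 1 to compound 3 and a 3.0-fold lower number (0.48 log units; beyond the scatter) from compound 2 to compound 4, 2.1-fold (0.32 log units) apart, within the scatter of two such steps. Within these four compounds, each change can therefore be carried from one core to the other without a detectable difference in step size, but this does not establish a real difference between compound 3 and compound 4, and two pairs per change say nothing about any further core.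

As far as these compounds go, it remains open whether an amine or a carboxylic acid in the place of methoxy would fit the same picture. From the compounds shown here alone, it also remains open whether a bromo or methyl group in the place of chloro would leave the cyano step as it stands here.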